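From Compound 2 to Compound 3

A few compounds are considered here, and "the series" means these few. Any claim that something is new, unique, unknown or untested is made for them only; others in the source may bear on it.

Two compounds sharing the same core were tested in an ADME assay on a cell-free system (plasma, Rattus norvegicus) for metabolic stability, read by LC-MS, with a stated time of 60 min, tested at 100 uM; on this read-out lower numbers stand for a less stable compound and higher numbers for a more stable compound. Compound 1 `COc1cc(C(=O)O)ccc1OCCCCOc1ccc(C(=O)CC(C)(C)C)c(O)c1C` gives 48%. Compound 2 `Cc1c(OCCCCOCOc2ccc(C(=O)O)cc2)ccc(C(=O)CC2CCCC2)c1O` gives 100%, the higher of the two numbers, beyond the scatter from compound 1. Compound 3 `Cc1c(OCCCCOc2ccc(C(=O)O)c(Cl)c2)ccc(C(=O)CC2CCCC2)c1O` has not been measured; it differs from compound 2 in one place: 4-carboxy-3-chlorophenyl in place of (4-carboxyphenoxy)methyl on an oxygen on a saturated carbon. Going by the values given here, no step between measured compounds exists to guide this change, so a moderate downward step a number 25 percentage points lower from compound 2 to compound 3 (beyond the scatter) is expected in this assay, leaning toward the lower number seen for compound 1 at 48%. Compound 3 is estimated at 75%, with a range from 45% to 100%.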

Compound 3, percent of the compound remaining: 97%
For compound 3 the middle estimate is 22 percentage points below the measured one, and the stated range covers the measured number.
By their numbers in this assay, from the lowest: compound 1; then compounds 3 and 2 (each within the scatter of the next).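

In this assay, putting 4-carboxy-3-chlorophenyl in place of (4-carboxyphenoxy)methyl on an oxygen on a saturated carbon gives a number 3 percentage points lower from compound 2 to compound 3 (within the scatter). Going by these compounds alone, for this pair, the two groups can be exchanged at this place without a change that stands out on this read-out, something the earlier compounds, which differ in more than one place, could not show. Nothing available gives a reason for this result. As far as these compounds go, whether the chlorine itself matters stays open, as the whole group changed at once. So does how an amine or a longer chain at this place would read in this assay.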